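A few compounds are considered here, and "the series" means these few. Any claim that something is new, unique, unknown or untested is made for them only; others in the source may bear on it.

Of the compounds shown here, two have been measured so far. Compound 1 `N/C(=N\NC(=S)N1CCCCC1)c1ccccn1` carries a piperidin-1-yl group on its thiocarbonyl carbon, and in a functional assay on A-431 cells (Homo sapiens) for cytotoxicity, read by MTT assay, with a stated time of 72 h, tested at 1 uM (on this read-out lower numbers stand for less inhibition of growth and higher numbers for more inhibition of growth at the one concentration tested), compound 1 gives 24.4%. Compound 2 `Cc1cccc(/C(N)=N/NC(=S)N2CCOCC2)n1` carries a morpholin-4-yl group at that place and differs from compound 1 in a second place as well; in this assay compound 2 gives 47.2%. Of the two numbers, that of compound 2 is the higher, and the gap to compound 1 lies beyond the scatter; because the two structures differ in more than one place, this pair says nothing about either change on its own.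

Compound 3 `Cc1cccc(/C(N)=N/NC(=S)N2CCCCC2)n1` is the next step from compound 2: piperidin-1-yl in place of morpholin-4-yl on a thiocarbonyl carbon. Going by the values given here, no measured pair isolates this exchange. Compound 3 shares its thiocarbonyl substituent with compound 1, which gives 24.4%, and the rest of its structure with compound 2, which gives 47.2%, so a value between the two is expected. The step from compound 2 to compound 3 is expected to be a number 12.2 percentage points lower from compound 2 to compound 3 (beyond the scatter), a downward move that may or may not clear the scatter. Compound 3 is therefore estimated at 35%, within a range from 15% to 55%.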

Compound 3, percent growth inhibition at one concentration: 35%
Compound 3: the middle estimate sits on the measured number at the digits printed, and the stated range covers the measured number.
By their numbers in this assay, from the lowest: compound 1; then compound 3; then compound 2.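

Compound 3 separates the two changes that the pair of compound 1 and compound 2 left tangled. With the methyl-bearing core held constant, piperidin-1-yl in place of morpholin-4-yl on a thiocarbonyl carbon gives, in this assay, a number 12.2 percentage points lower from compound 2 to compound 3 (beyond the scatter), so the exchange at this position has a modest effect of its own on the read-out. With piperidin-1-yl held constant, methyl in place of hydrogen on an aromatic carbon gives a number 10.6 percentage points higher from compound 1 to compound 3 (beyond the scatter), so the second change also has its own modest step, and no data shown here explain either one.

Going by these compounds, each step has been read only once and against a single background, so it remains open whether the methyl step would hold with morpholin-4-yl on the thiocarbonyl carbon, or the morpholin-4-yl to piperidin-1-yl step with hydrogen on the aromatic carbon. On these data alone, it also remains open how a piperazin-1-yl or dimethylamino group on the thiocarbonyl carbon, or an ethyl or methoxy group in place of the methyl, would fall relative to these compounds.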